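Swapping the Aryl Group on the Thioether Sulfur

A few compounds are considered here, and "the series" means these few. Any claim that something is new, unique, unknown or untested is made for them only; others in the source may bear on it.

Measured so far:
Compound 1, `COc1ccc(SCc2ccc(/C=C/C(=O)Nc3ccccc3N)cc2)cc1OC`: 46.4%
Compound 2, `Cc1ccc(SCc2ccc(C(=O)Nc3ccccc3N)cc2)cc1`: 67%

In a functional assay on A-375 cells (Homo sapiens) for inhibition, read by CCK-8 assay, with a stated time of 72 h, tested at 8 uM (a higher number here means more inhibition of growth at the concentration tested, a lower number less inhibition of growth), compound 1 gives 46.4%, the lower of the two numbers measured. Compound 2 gives 67%, a gap that lies beyond the usual scatter. Compound 3, `Nc1ccccc1NC(=O)/C=C/c1ccc(CSc2ccc(C(F)(F)F)cn2)cc1`, has not yet been measured. It differs from compound 1 in one place: 5-(trifluoromethyl)pyridin-2-yl in place of 3,4-dimethoxyphenyl on a sulfur. For the measured compounds named here, no measured pair shows this change, so its effect is unknown from these data. A step of modest size is expected, with no clear direction, and it may well stay within the scatter. Compound 3 is estimated at 50%, between 30% and 70%, meaning an expected step of a number 3.6 percentage points higher from compound 1 to compound 3 (within the scatter).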

Compound 3, percent growth inhibition at one concentration: 3.96%
Compound 3: middle estimate off by 46 percentage points, on the high side, outside the stated range (below it).
By their numbers in this assay, from the lowest: compound 3; then compound 1; then compound 2.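

The aryl group on the thioether sulfur proves to be a sensitive place. In this assay, 5-(trifluoromethyl)pyridin-2-yl in place of 3,4-dimethoxyphenyl gives a number 42.4 percentage points lower from compound 1 to compound 3 (beyond the scatter), although both groups count the same number of heavy atoms. Nothing available explains this fall. From the compounds shown here alone, the swap changes the ring and its substituents together, so the separate shares of the ring nitrogen, the trifluoromethyl and the lost methoxy groups remain open. An unsubstituted pyridin-2-yl or a phenyl carrying trifluoromethyl on the sulfur would help tell them apart.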